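The compounds below may be only part of what the source reports. "The series", "measured", "known", "first", "only" and "open" are said of these compounds alone.

Working notes on the series, all read in an ADME assay on a cell-free system (plasma, Mus musculus) for protein binding; a lower number here means a smaller unbound share, a higher number a larger unbound share of the compound. Compound 1 (`CC(C)COc1ncc(-c2cn(C)c3cc(C(=O)NS(C)(=O)=O)ccc23)cc1Cl`) gives 0.002. Compound 2 (`Cn1cc(-c2ccc(C(F)(F)F)cc2)c2cc(F)c(C(=O)NS(=O)(=O)C3CC3)cc21`) gives 0.0035, within the scatter of compound 1. Compound 3 (`Cn1nc(-c2ccc(C(F)(F)F)cc2)c2cc(F)c(C(=O)NS(=O)(=O)C3CC3)cc21`) gives 0.008, and this gap to compound 1 lies beyond the scatter. Compound 4 (`CC(C)COc1ncc(-c2cn(C)c3cc(C(=O)NS(C)(=O)=O)c(F)cc23)cc1Cl`) is compound 1 with fluoro in place of hydrogen on an aromatic carbon, ortho to a (methylsulfonyl)carbamoyl group: fluoro in place of hydrogen on an aromatic carbon. Within the data shown here, no measured pair isolates this change, so the expectation rests on the small size of the change alone. No step beyond the scatter is expected in this assay, and the estimated step of a 1.3-fold higher number from compound 1 to compound 4 (0.10 log units; within the scatter) has no firm direction. Compound 4 is estimated at 0.0025, with an expected range of 0.0012 to 0.005.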

Compound 4, unbound fraction: 0.002
Compound 4: middle estimate off by 1.3-fold (0.10 log units), on the high side; the measured number falls inside the stated range.
By their numbers in this assay, from the lowest: compounds 1, 4 and 2 (each within the scatter of the next); then compound 3.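

In this assay, among these compounds, fluoro in place of hydrogen on an aromatic carbon, ortho to a (methylsulfonyl)carbamoyl group, gives no change at the digits printed from compound 1 to compound 4 (within the scatter) and is the only single-place change read so far. At this position, on the core of compound 1, the unbound share therefore shows no step beyond the scatter with this change. Nothing at hand explains the result.

From the compounds shown here alone, whether a chloro, methoxy or amine group at the same position would leave the unbound share as flat remains open. Going by these compounds, whether fluoro behaves alike on another core also remains open.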